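The compounds below may be only part of what the source reports. "The series", "measured", "known", "first", "only" and "open" are said of these compounds alone.

Of the compounds shown here, two carry numbers so far. In an assay on isolated protein for agonist activity at nuclear receptor subfamily 1 group D member 1 (Homo sapiens), read by FRET, with a stated time of 1 h (a higher number here means that more compound is needed for the effect, a lower number that less compound is needed), compound 2 `O=[N+]([O-])c1ccc(CN(Cc2ccc(Cl)cc2)Cc2ccccc2F)s1` gives 63 nM, the lower of the two numbers measured; compound 1 `CC(C)(C)OC(=O)CN(Cc1ccc(Cl)cc1)Cc1ccc([N+](=O)[O-])s1` gives 500 nM in this assay. For the measured compounds named here, the one step between them, a 7.9-fold lower number from compound 1 to compound 2 (0.90 log units; beyond the scatter), is the only measured change at the saturated chain carbon bound to the amine nitrogen, and it exchanges an ester-type group for an aromatic ring rather than one aromatic ring for another.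

Compound 3 `Cc1cc(Cl)ccc1CN(Cc1ccc(Cl)cc1)Cc1ccc([N+](=O)[O-])s1` differs from compound 2 by 4-chloro-2-methylphenyl in place of 2-fluorophenyl on a saturated chain carbon bound to an amine nitrogen. Going by the values given here, no measured step bears directly on an aryl-for-aryl exchange at this position; the step from compound 1 to compound 2 shows only that the group at this carbon can move the number by a modest amount. With both compound 2 and compound 3 carrying an aromatic ring there, a step within or just beyond the scatter is expected in either direction, and the estimate for compound 3 is 55 nM, with a range from 20 nM to 160 nM, corresponding to an expected step of a 1.1-fold lower number from compound 2 to compound 3 (0.06 log units; within the scatter).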

Compound 3, half-maximal effective concentration: 50 nM
Estimate against measurement, compound 3: 1.1-fold (0.04 log units) above; low and high end bracket the measured number.
By their numbers in this assay, from the lowest: compounds 3 and 2 (each within the scatter of the next); then compound 1.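

In this assay, the only aryl-for-aryl exchange shown on the saturated chain carbon bound to the amine nitrogen gives a 1.3-fold lower number from compound 2 to compound 3 (0.10 log units; within the scatter), so replacing 2-fluorophenyl with 4-chloro-2-methylphenyl does not separate compound 2 from compound 3, even though the ring's fluorine gives way to a chlorine and a methyl. The comparison with the ester-type group now rests on two different aromatic rings, with a 10-fold lower number from compound 1 to compound 3 (1.00 log units; beyond the scatter) alongside a 7.9-fold lower number from compound 1 to compound 2 (0.90 log units; beyond the scatter), and neither aromatic compound goes against this pattern among the three compounds shown. No measurement here accounts for either step, and this series offers no independent data bearing on them.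

How a cyclohexyl ring, a pyridine ring or a carboxylic acid on this carbon would compare remains open, so the compounds shown do not tell whether an aromatic carbon ring is needed there or the tert-butoxycarbonyl group is simply less favourable. The rest of the core is the same in all three compounds, which leaves open whether the same small step between these two aromatic groups would hold on a changed core.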